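A few compounds are considered here, and "the series" means these few. Any claim that something is new, unique, unknown or untested is made for them only; others in the source may bear on it.

Measured compounds in an assay on isolated protein (Cavia porcellus) with Sigma non-opioid intracellular receptor 1 (Homo sapiens) as the target, read by radioligand binding; a higher number here means a weaker inhibitor, a lower number a stronger inhibitor:
compound 1 , `O=c1cc(-c2ccccc2Cl)oc2ccc(OCCCCCCN3CCC(O)CC3)cc12`, gives 29 nM
compound 2 , `O=c1cc(-c2cccs2)oc2ccc(OCCCCCCN3CCC(O)CC3)cc12`, gives 232 nM
compound 3 , `O=c1cc(C2CCCC2)oc2ccc(OCCCCCCN3CCC(O)CC3)cc12`, gives 55 nM

Compound 3 stands at the second highest of the three numbers in this assay. Its nearest neighbour is compound 1: the step of a 1.9-fold higher number from compound 1 to compound 3 (0.28 log units; within the scatter) stays within the scatter. Its furthest neighbour is compound 2: the step of a 4.2-fold lower number from compound 2 to compound 3 (0.63 log units; beyond the scatter) lies beyond the scatter.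

Compound 4, `O=c1cc(C2CCCCC2)oc2ccc(OCCCCCCN3CCC(O)CC3)cc12`, is not yet measured. The change from compound 3 to compound 4 is cyclohexyl in place of cyclopentyl on an aromatic carbon. Going by the values given here, no measured step swaps one saturated carbocycle for another; the steps that bear on the position are a 1.9-fold higher number from compound 1 to compound 3 (0.28 log units; within the scatter) and a 4.2-fold lower number from compound 2 to compound 3 (0.63 log units; beyond the scatter), which show that this position accepts a cyclopentyl in place of an aromatic ring with a number close to compound 1 and a lower number than compound 2. Going from cyclopentyl to cyclohexyl at the same position is a smaller change than either of those, so no step beyond the scatter is expected in this assay, in either direction. Compound 4 is therefore estimated at 50 nM, with a range of 20 nM to 140 nM, meaning an expected step of a 1.1-fold lower number from compound 3 to compound 4 (0.04 log units; within the scatter).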

Compound 4, half-maximal inhibitory concentration: 46 nM
Beside the measured number, compound 4's estimate is 1.1-fold (0.04 log units) above it, and the stated range covers the measured number.
By their numbers in this assay, from the lowest: compounds 1, 4 and 3 (each within the scatter of the next); then compound 2.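

In this assay, the swap of one saturated carbocycle for another at this position, on the aromatic carbon next to the ring oxygen, gives a 1.2-fold lower number from compound 3 to compound 4 (0.08 log units; within the scatter) and so does not separate a five-membered ring from a six-membered one. The cyclohexyl group keeps the same relation to the aromatic groups as cyclopentyl: a 5.0-fold lower number from compound 2 to compound 4 (0.70 log units; beyond the scatter) places thiophen-2-yl apart from it, whereas a 1.6-fold higher number from compound 1 to compound 4 (0.20 log units; within the scatter) does not separate it from 2-chlorophenyl, so among these four compounds only compound 2 stands apart. The material shown offers no measured basis for explaining this arrangement.

As far as these compounds go, whether a plain phenyl, a cyclohexyl carrying an amine or a carboxylic acid, or an open chain such as tert-butyl would group with compound 1, compound 3 and compound 4 or with compound 2 remains open. Also open is whether the gap seen for compound 2 extends to thiophen-3-yl or furan-2-yl at the same position, and how any of these compounds behaves at a second target.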